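The source may report more compounds than this note shows. Statements on the series, on what has been measured and on what is new or still open speak of the compounds shown alone.

Working notes on the series, read in a functional assay on MCF7 cells (Homo sapiens) for inhibition, read by CCK-8 assay, with a stated time of 48 h; a lower number here means a stronger inhibitor of growth, a higher number a weaker inhibitor of growth. Compound 1 (`Cc1ccccc1Nc1nc(Nc2ccc(N3CCN(C)CC3)cn2)ncc1Cl`) gives 5210 nM, compound 2 (`CN1CCN(c2ccc(Nc3ncc(Cl)c(Nc4ccccc4)n3)nc2)CC1`) gives 51800 nM, and compound 3 (`CN1CCN(c2ccc(Nc3ncc(Cl)c(NCc4ccccc4)n3)nc2)CC1`) gives 17300 nM. Compound 3 therefore holds the middle of the three numbers. Replacing phenyl with benzyl reads a 3.0-fold lower number from compound 2 to compound 3 (0.48 log units; beyond the scatter), while replacing 2-methylphenyl with benzyl reads a 3.3-fold higher number from compound 1 to compound 3 (0.52 log units; beyond the scatter).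

Compound 4 (`CN1CCN(c2ccc(Nc3ncc(Cl)c(NCc4ccc(C(F)(F)F)cc4)n3)nc2)CC1`) differs from compound 3 as follows: trifluoromethyl in place of hydrogen on an aromatic carbon. In words, this is trifluoromethyl in place of hydrogen on an aromatic carbon, para to a large group. Among the measured compounds shown here, no measured compound carries trifluoromethyl, and none carries a group on benzyl, so the evidence is indirect. The closest guide is the methyl on the phenyl of compound 1, whose removal reads a 9.9-fold higher number from compound 1 to compound 2 (1.00 log units; beyond the scatter). Read in reverse, that step points to a lower number when a group replaces hydrogen, but it comes from a different group in a different setting. A smaller step in the same direction is expected, and no change beyond the scatter remains possible. The expected outcome is a 2.2-fold lower number from compound 3 to compound 4 (0.33 log units; beyond the scatter). For compound 4 the estimated value is 8000 nM, with an expected range of 2500 nM to 22000 nM.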

Compound 4, concentration for 50% growth inhibition: 28400 nM
For compound 4 the middle estimate is 3.6-fold (0.55 log units) below the measured one, and the stated range ends below it.
By their numbers in this assay, from the lowest: compound 1; then compounds 3, 4 and 2 (each within the scatter of the next, the first and the last beyond it).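

In this assay, trifluoromethyl on an aromatic carbon of the benzyl group, para to a large group, gives a change that cannot be told from the scatter: a 1.6-fold higher number from compound 3 to compound 4 (0.22 log units; within the scatter). The 4-(trifluoromethyl)benzyl group likewise does not separate compound 4 from the phenyl group of compound 2, a 1.8-fold lower number from compound 2 to compound 4 (0.26 log units; within the scatter), while the 2-methylphenyl group of compound 1 keeps its lower number, a 5.5-fold higher number from compound 1 to compound 4 (0.74 log units; beyond the scatter). Nothing in the available data accounts for these results.

Open, on these data alone, is whether this silence holds only for trifluoromethyl or also for a methyl, a methoxy, an amine or a carboxylic acid on the same aromatic carbon. Also open, as far as these compounds go, is how a phenethyl group, with its longer chain, would read in place of benzyl.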